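Nitro-to-methoxy swap on a chloro-benzothiazole naphthol scaffold

A few compounds are considered here, and "the series" means these few. Any claim that something is new, unique, unknown or untested is made for them only; others in the source may bear on it.

Of the compounds shown here, three have been measured in a functional assay on MCF7 cells (Homo sapiens) for antiproliferative activity, read by MTT assay, with a stated time of 48 h; a lower number here means a stronger inhibitor, a higher number a weaker inhibitor. Compound 1 `COc1ccc2nc(NC(c3cn(-c4ccccc4)nc3-c3cccc([N+](=O)[O-])c3)c3c(O)ccc4ccccc34)sc2c1` gives 26800 nM. Compound 2 `COc1cccc(-c2nn(-c3ccccc3)cc2C(Nc2nc3ccc(OC)cc3s2)c2c(O)ccc3ccccc23)c1` differs from compound 1 in one place, (methoxy in place of nitro on an aromatic carbon). Compound 2 gives 62600 nM; this change brought a 2.3-fold higher number from compound 1 to compound 2 (0.37 log units; beyond the scatter). Compound 3 `O=[N+]([O-])c1cccc(-c2nn(-c3ccccc3)cc2C(Nc2nc3ccc(Cl)cc3s2)c2c(O)ccc3ccccc23)c1` carries a different core, the difference being (chloro in place of methoxy on an aromatic carbon), and gives 19700 nM; the step of a 1.4-fold lower number from compound 1 to compound 3 (0.13 log units; within the scatter) is within the scatter, so compound 1 and compound 3 are not distinguished here.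

Compound 4 `COc1cccc(-c2nn(-c3ccccc3)cc2C(Nc2nc3ccc(Cl)cc3s2)c2c(O)ccc3ccccc23)c1` has not yet been measured. It relates to compound 3 as compound 2 relates to compound 1: the difference is methoxy in place of nitro on an aromatic carbon, and the place around the change is the same as in the earlier pair, so it is the same change on the other core. Resting on the earlier step from compound 1 to compound 2, compound 4 is expected to show a 2.3-fold higher number from compound 3 to compound 4 (0.36 log units; beyond the scatter), a modest step in the same direction. The estimate for compound 4 in this assay is therefore 45000 nM, with a plausible range from 24000 nM to 90000 nM.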

Compound 4, half-maximal inhibitory concentration: 36000 nM
Compound 4: the middle estimate sits 1.3-fold (0.10 log units) above what was measured; the range from low to high includes it.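

On the core of compound 3, the swap from 3-nitrophenyl to 3-methoxyphenyl gave a 1.8-fold higher number from compound 3 to compound 4 (0.26 log units; within the scatter) in this assay, and this step cannot be told apart from the step on the core of compound 1: the same change on two cores in this assay, a 2.3-fold higher number (0.37 log units; beyond the scatter) from compound 1 to compound 2 and a 1.8-fold higher number (0.26 log units; within the scatter) from compound 3 to compound 4, 1.3-fold (0.11 log units) apart, within the scatter of two such steps The second change, chloro in place of methoxy, gave a 1.7-fold lower number from compound 2 to compound 4 (0.24 log units; within the scatter), and it too matches its earlier counterpart: the same change on two cores in this assay, a 1.4-fold lower number (0.13 log units; within the scatter) from compound 1 to compound 3 and a 1.7-fold lower number (0.24 log units; within the scatter) from compound 2 to compound 4, 1.3-fold (0.11 log units) apart, within the scatter of two such steps This shows that, within the scatter, each change had a similar size on the two cores compared, but it rests on a single pair of steps per change in one assay, the steps from compound 3 to compound 4 and from compound 2 to compound 4 are not distinguishable from scatter when read alone, and nothing here shows that the match would hold on any further core or explains why it arises.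

What the compounds shown leave open is whether an amine or a carboxylic acid in place of the nitro would fit the same picture. They also leave open whether a longer chain in place of the methoxy would do so.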